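Swapping the Amide Substituent on a Shared Anti-Inflammatory Core

The source may hold more compounds than are shown below. What is called first, only, known or untested is meant among the compounds shown, and "the series" means these compounds.

Of the compounds shown here, three sharing one core have been tested in a functional assay on the whole organism (strain Wistar) for inhibition, with Rattus norvegicus as the target, read by paw edema, with stated times of 60 min and 6 h, at a dose of 100 mg/kg by the oral route; a lower number here means less inhibition, a higher number more inhibition at the dose given (going by the name of the read-out). Compound 1 `CCN(CC)C(=O)CC1CCc2cc(OC)c(OC)cc21` gives 31.5%. Compound 2 `COc1cc2c(cc1OC)C(CC(=O)NC(C)(C)C)CC2` gives 31.5%, and compound 3 `COc1cc2c(cc1OC)C(CC(=O)NC1CCCC1)CC2` gives 40.7%. Compound 2 stands level with compound 1 at the digits shown, and together they hold the lowest two numbers of the three; the step of a number 9.2 percentage points higher from compound 2 to compound 3 (within the scatter) lies within the scatter, so no ordering among the three can be claimed.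

Compound 4 `COc1cc2c(cc1OC)C(CC(=O)N1CCNCC1)CC2` has not yet been measured in this assay. It differs from compound 2 by piperazin-1-yl in place of (tert-butyl)amino on a carbonyl carbon. Going by the values given here, the steps that bear on this change are the two earlier swaps at the same carbonyl carbon: no change at the digits printed from compound 1 to compound 2 (within the scatter) and a number 9.2 percentage points higher from compound 1 to compound 3 (within the scatter). Both stayed within the scatter, even though the groups differed in shape and size, so changing the group on the carbonyl carbon has so far left this assay unmoved. The step of a number 1.5 percentage points higher from compound 2 to compound 4 (within the scatter) is therefore expected to stay within the scatter. Compound 4 is estimated at 33%, with a range from 18% to 48%.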

Compound 4, a percentage reported as inhibition, in the whole organism at one dose (the size of the read-out at that dose, not a potency): 33.3%
Compound 4: middle estimate off by 0.3 percentage points, on the low side; low and high end bracket the measured number.
By their numbers in this assay, from the lowest: compounds 1, 2, 4 and 3 (each within the scatter of the next).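

Piperazin-1-yl puts a six-membered non-aromatic ring with a second nitrogen on the carbonyl carbon, something none of the earlier groups carried, yet this assay gives a number 1.8 percentage points higher from compound 2 to compound 4 (within the scatter), a number 1.8 percentage points higher from compound 1 to compound 4 (within the scatter) and a number 7.4 percentage points lower from compound 3 to compound 4 (within the scatter). This position has now taken diethylamino, (tert-butyl)amino, cyclopentylamino and piperazin-1-yl, and every step among them stays within the scatter, so even this ring with its extra hydrogen-bond acceptor does not separate compound 4 from the others. Nothing available explains why these groups read alike.

As far as these compounds go, whether a benzylamino group or a free carboxylic acid at this carbonyl carbon would give a step beyond the scatter remains open. Also open, from the compounds shown here alone, is whether replacing the methoxy groups on the shared core would shift the number further than any swap seen here.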